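Bulkier amino acid side chain at the amide carbonyl

This account rests on a few compounds, and the source may have more. Where it says the series, first, only, none or still open, it means among the compounds named here.

The series shares one core bearing a piperazine amide. Compound 1 `CC(C)(C)[C@@H](N)C(=O)N1CCN(CCCOc2ccc(C(=O)C3CC3)cc2)CC1` gives 19100 nM in an assay for binding affinity to histamine H2 receptor (Homo sapiens); on this read-out lower numbers stand for stronger inhibition and higher numbers for weaker inhibition. Compound 2 `CNCC(=O)N1CCN(CCCOc2ccc(C(=O)C3CC3)cc2)CC1` gives 79400 nM, the highest number of the three; compound 3 `CCCCCC(=O)c1ccc(OCCCN2CCN(C(=O)[C@@H](C)N)CC2)cc1` gives 40700 nM, within the scatter of compound 2. Within the data shown here, the one step that bears on the change is a 4.2-fold higher number from compound 1 to compound 2 (0.62 log units; beyond the scatter). Compound 4 `N[C@H](CC1CCCCC1)C(=O)N1CCN(CCCOc2ccc(C(=O)C3CC3)cc2)CC1` carries 1-amino-2-cyclohexylethyl in place of (methylamino)methyl on a carbonyl carbon, again a bulky substituent on that carbonyl carbon, so the step is expected to roughly reverse the earlier one and yield a lower number in this assay, beyond the scatter. Compound 4 is therefore estimated at 20000 nM, with a range from 7000 nM to 60000 nM, corresponding to an expected step of a 4.0-fold lower number from compound 2 to compound 4 (0.60 log units; beyond the scatter).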

Compound 4, inhibition constant: 20400 nM
Compound 4: middle estimate off by 1.0-fold (0.01 log units), on the low side; the range from low to high includes it.
By their numbers in this assay, from the lowest: compounds 1, 4, 3 and 2 (each within the scatter of the next, the first and the last beyond it).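

In this assay, a second large group on the carbonyl carbon also gives a lower number than the (methylamino)methyl group (a 3.9-fold lower number from compound 2 to compound 4 (0.59 log units; beyond the scatter)), so the earlier drop is not peculiar to the 1-amino-2,2-dimethylpropyl group. Cyclohexylmethyl in place of tert-butyl makes no readable difference (a 1.1-fold higher number from compound 1 to compound 4 (0.03 log units; within the scatter)). (No measurement shown here accounts for this result)

Compounds 1 and 4 differ from compound 2 both in size and in carrying an unmethylated amine, so a plain aminomethyl group would be needed to separate the two changes. From the compounds shown here alone, how a carboxylic acid or a phenyl ring on that side chain would fare remains open.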